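Trading a chlorobenzyl for a pentyl chain

The source may report more compounds than this note shows. Statements on the series, on what has been measured and on what is new or still open speak of the compounds shown alone.

For the measured compounds named here, compound 1 `CN1CCC[C@@H]1Cn1nc(Cc2cccc(Cl)c2)c2ccccc2c1=O` is the only member of this set with a definite number: in an assay for binding affinity to Alpha-1A adrenergic receptor (Homo sapiens) (a higher number here means a weaker inhibitor, a lower number a stronger inhibitor), compound 1 gives 398 nM. Compound 2 `CN1CCC[C@@H]1Cn1nc(Cc2ccc(C(C)(C)C)cc2)c2ccccc2c1=O` reaches only a limit of this assay, > 1990 nM. Compound 3 `COC(=O)c1ccc(Cc2nn(C[C@H]3CCCN3C)c(=O)c3ccccc23)cc1` likewise stops at a limit, > 1990 nM. The step that the two limits leave unreadable from compound 2 to compound 3 cannot be read, because the limit of > 1990 nM in this assay, at which 2 of the 3 values shown sit, holds both of its ends. Compound 4 `CCCCCc1nn(C[C@H]2CCCN2C)c(=O)c2ccccc12` differs from compound 1 by butyl in place of 3-chlorophenyl on a saturated chain carbon bound to an aromatic carbon. No measured step touches a change of this kind; the one step shown swaps a substituent on an aromatic ring that here disappears altogether, and its size is unreadable. Compound 1 at 398 nM is the only anchor. Compound 4 is expected to bind more weakly, an estimated step of a 2.8-fold higher number from compound 1 to compound 4 (0.44 log units; beyond the scatter). The expected value of compound 4 in this assay is 1100 nM, between 350 nM and 3500 nM.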

Compound 4, inhibition constant: 501 nM
Compound 4: middle estimate off by 2.2-fold (0.34 log units), on the high side, and the stated range covers the measured number.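

In this assay, butyl in place of 3-chlorophenyl on a saturated chain carbon bound to an aromatic carbon gives a 1.3-fold higher number from compound 1 to compound 4 (0.10 log units; within the scatter). For the compounds shown here, this is the only readable step in the set, and it shows that in this pair the chlorinated aromatic ring can leave this position without a change beyond the scatter. Nothing measured here gives a cause for this result.

Going by these compounds, whether a shorter propyl chain or a longer heptyl chain would hold this level stays open. So does the effect of an amine at the end of the pentyl chain.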